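Removing One Methoxy Group on a Pyrazole Chalcone Core

This account rests on a few compounds, and the source may have more. Where it says the series, first, only, none or still open, it means among the compounds named here.

Compound 1 `COc1cc(-c2cc(/C=C/C(=O)c3ccc(N)cc3)[nH]n2)cc(OC)c1OC` and compound 2 `COc1ccc(-c2cc(/C=C/C(=O)c3ccc(N)cc3)[nH]n2)cc1OC` share a core; compound 2 differs only by hydrogen in place of methoxy on an aromatic carbon. In a functional assay on T47D cells (Homo sapiens) for cytotoxicity, read by sulforhodamine B assay, with a stated time of 48 h, tested at 0.01 uM (a higher number here means a weaker effect of the compound at the concentration tested, a lower number a stronger effect), compound 1 gives 83%, and compound 2 gives 85%; the step of a number 2 percentage points higher from compound 1 to compound 2 (within the scatter). Compound 3 `COc1cc(C(=O)/C=C/c2cc(-c3cc(OC)c(OC)c(OC)c3)n[nH]2)cc(OC)c1OC` has a different core, and the difference between the two cores is not broken down here; in this assay compound 3 gives 91%. Compound 4 `COc1ccc(-c2cc(/C=C/C(=O)c3cc(OC)c(OC)c(OC)c3)[nH]n2)cc1OC` is compound 3 after the same change, (hydrogen in place of methoxy on an aromatic carbon). Because the earlier step of a number 2 percentage points higher from compound 1 to compound 2 (within the scatter) stayed within the scatter, the step from compound 3 to compound 4 is expected to be small as well, a number 1 percentage points higher from compound 3 to compound 4 (within the scatter). Compound 4 is therefore estimated to give 92% in this assay, expected between 80% and 100%.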

Compound 4, a percentage reported as activity, at one concentration (the size of the read-out at that concentration, not a potency): 91%
Beside the measured number, compound 4's estimate is 1 percentage points above it; measured number inside the range.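

In this assay, hydrogen in place of methoxy on an aromatic carbon gives no change at the digits printed from compound 3 to compound 4 (within the scatter). Set beside the earlier step, the change reads the same on both cores: the same change on two cores in this assay, a number 2 percentage points higher (within the scatter) from compound 1 to compound 2 and no change at the digits printed (within the scatter) from compound 3 to compound 4, 2 percentage points apart, within the scatter of two such steps

Going by these compounds alone, this shows only that removing this methoxy group made no readable difference on these two cores, at the single concentration tested. It does not show that the same would hold on another core or at another concentration, nor that the methoxy groups are unimportant in general.

The compounds shown leave open whether a different group at this place, such as a hydroxyl group or a chlorine atom, would move the number beyond the scatter. They also leave open how a carboxylic acid in place of the amine of compound 2 would read.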